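Swapping Chloro for Fluoro on a Low-Toxicity Scaffold

The compounds below may be only part of what the source reports. "The series", "measured", "known", "first", "only" and "open" are said of these compounds alone.

Compound 1, `CC(C)(C)OC(=O)Nc1ncc(C(Oc2ccc3cc(Br)ccc3c2)c2ccc(Cl)cc2)s1`: in an ADME assay on HepG2 2.2.15 cells (Homo sapiens) for cytotoxicity (on this read-out lower numbers stand for higher toxicity in this test and higher numbers for lower toxicity in this test), compound 1 gives > 50000 nM, which is a limit of the assay.
Compound 2, `CCN(CC)C(=O)Nc1ncc(C(Oc2ccc3cc(Br)ccc3c2)c2ccc(Cl)cc2)s1`: in this assay compound 2 gives "not toxic" (no number reported).
Compound 3, `COc1ccc(C(=O)Nc2ncc(C(Oc3ccc4cc(Br)ccc4c3)c3ccc(Cl)cc3)s2)cc1`: in this assay compound 3 gives > 50000 nM, again a limit of the assay.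

Compound 3 stands at the ceiling of the numbers shown: its value is a limit, not a measured number, and it shares (the limit of > 50000 nM in this assay, at which 2 of the 3 values shown sit). Compound 2 carries no number at all. Going by the values given here, the only step between measured compounds, a step that the two limits leave unreadable from compound 1 to compound 3, puts 4-methoxyphenyl in place of tert-butoxy on a carbonyl carbon and runs from one limit to another, so its size cannot be read. Compound 4, `COc1ccc(C(=O)Nc2ncc(C(Oc3ccc4cc(Br)ccc4c3)c3ccc(F)cc3)s2)cc1`, differs from compound 3 by fluoro in place of chloro on an aromatic carbon, para to a large group. No measured step touches this position, so nothing shown points in either direction. The expectation for compound 4 in this assay is a step that the limit leaves unreadable from compound 3 to compound 4, nothing beyond the scatter, most likely reported once more as a limit. Compound 4 is estimated at 80000 nM, within a range from 30000 nM to 300000 nM.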

Compound 4, half-maximal cytotoxic concentration: > 50000 nM
Compound 4: only a limit was reported; the forecaster's own chance of this, stated with the estimate: 85%; the middle value lies beyond the limit too.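

Compound 3 and compound 4 each give only a limit, so the change from chloro to fluoro has no readable size: the limit of > 50000 nM in this assay, at which 3 of the 4 values shown sit. The compounds shown leave open whether any of them truly differs from another in this assay and which change to the shared core would give a measured number.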